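The source may report more compounds than this note shows. Statements on the series, on what has been measured and on what is new or still open speak of the compounds shown alone.

For the measured compounds named here, in a functional assay on the whole organism (strain STD-ddY) with Mus musculus as the target, with stated times of 1 h and 24 h (a higher number here means that more compound is needed for the effect, a lower number that less compound is needed), compound 2 `CSc1nc2ccccc2n1C1CCN(CCCC(c2ccc(F)cc2)c2ccc(F)cc2)CC1` gives 2.4 mg/kg, the only plain number in the pair measured so far. Compound 1 `Cc1nc2ccccc2n1C1CCN(CCCC(c2ccc(F)cc2)c2ccc(F)cc2)CC1` reaches only a limit of the assay, > 3 mg/kg. The step of an at least 1.2-fold lower number from compound 1 to compound 2 (0.09 log units; that floor lies within the scatter) therefore stands on the limit of > 3 mg/kg in this assay, at which 1 of the 2 values shown sits, and settles little. Compound 3 `OCCSc1nc2ccccc2n1C1CCN(CCCC(c2ccc(F)cc2)c2ccc(F)cc2)CC1` differs from compound 2 by hydroxymethyl in place of hydrogen on a saturated chain carbon bound to a sulfur. Going by the values given here, no measured step touches this change; the single step known, methylsulfanyl for methyl, sits at another place and its floor lies within the scatter. With nothing pointing to a shift, compound 3 is expected to stay close to its parent, a step of no change at the digits printed from compound 2 to compound 3 (within the scatter). The estimate for compound 3 is 2.4 mg/kg, ranging from 1 mg/kg to 6 mg/kg.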

Compound 3, dose for half-maximal effect: > 3 mg/kg
Compound 3 gave a limit, no number; the forecaster's own chance of this, stated with the estimate: 25%; at least 1.2-fold (0.09 log units) between middle value and limit.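

In this assay compound 3 gives > 3 mg/kg as a limit of the assay, not a number. Hydroxymethyl in place of hydrogen on a saturated chain carbon bound to a sulfur, the first change shown at this place, gives an at least 1.2-fold higher number from compound 2 to compound 3 (0.09 log units; that floor lies within the scatter) and so establishes no loss. For the compounds shown here, compound 2 remains the only plain number: the limit of > 3 mg/kg in this assay, at which 2 of the 3 values shown sit.

The step between compound 1 and compound 3 cannot be read, as both values are limits. Going by these compounds, whether an amine, a carboxylic acid or a longer chain at this place would give a plain number stays open.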